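Chloro added to a biphenyl side chain: a limit-bound series

The compounds below may be only part of what the source reports. "The series", "measured", "known", "first", "only" and "open" are said of these compounds alone.

The measured compounds so far:
Compound 1 `CC(C)=CCC[C@@](C)(/C=C/c1ccccc1)/C=C/c1ccc(O)cc1` gives, in a functional assay on Raji cells (Homo sapiens) for cytotoxicity, with a stated time of 72 h (a lower number here means that less compound is needed, a higher number that more compound is needed for the effect), only a limit of > 26000 nM.
Compound 2 `CC(C)=CCC[C@](C)(/C=C/c1ccc(O)cc1)/C=C/c1cccc(Cl)c1` likewise gives only a limit of > 26000 nM in this assay.
Compound 3 `C=C[C@@](C)(/C=C/c1ccc(-c2ccc(Cl)cc2)cc1)CCC=C(C)C` also gives only a limit of > 26000 nM in this assay.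

Compound 1 and compound 2 differ by a single change, (chloro in place of hydrogen on an aromatic carbon). Because both values are limits, the step that the two limits leave unreadable from compound 1 to compound 2 cannot be read: its size is not known. Compound 3 carries a different core, and the difference between the two cores is not broken down here; all that can be said is that compound 1 and compound 3 both sit at the limit.

Compound 4 `C=C[C@@](C)(/C=C/c1ccc(-c2ccc(Cl)c(Cl)c2)cc1)CCC=C(C)C` has not yet been measured. It differs from compound 3 by chloro in place of hydrogen on an aromatic carbon. Among the measured compounds shown here, this is the same kind of change as the one from compound 1 to compound 2, though not the same: around the new chloro in compound 4 the place is also ortho to a chloro group (1 heavy atom), whereas in compound 2 it is only meta to a large group.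

The evidence points one way: the limit of > 26000 nM in this assay, at which 3 of the 3 values shown sit. On that basis the step from compound 3 to compound 4 is expected to be small, roughly a step that the limit leaves unreadable from compound 3 to compound 4. Compound 4 is therefore expected to give about 30000 nM, most likely again reported only as a limit. The range expected for compound 4 runs from 10000 nM to 100000 nM.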

Compound 4, half-maximal effective concentration: > 26000 nM
Compound 4 ended at the assay's limit (the forecaster's own chance of this, stated with the estimate: 85%); the middle value lies beyond the limit too.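

In this assay compound 4 gives > 26000 nM, which is a limit and not a number. Compound 3 also sits at a limit, so the step between compound 3 and compound 4 cannot be read. The compounds shown leave open how far any of them lies from that limit, and whether adding a chloro changes the result in this assay at all.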